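A Phenylalkyl Chain in Place of the Pyridine Ester

This account rests on a few compounds, and the source may have more. Where it says the series, first, only, none or still open, it means among the compounds named here.

Compound 2 `O=C(OCC1COCCOCCOCCOCCOCCO1)c1cccnc1` carries a pyridin-3-yl group on the carbonyl carbon of the shared core. In a functional assay on SW1573 cells (Homo sapiens) for inhibition, read by sulforhodamine B assay, with a stated time of 48 h (a higher number here means a weaker inhibitor of growth, a lower number a stronger inhibitor of growth), compound 2 gives > 100000 nM, which is a limit of the assay rather than a number, as the limit of > 100000 nM in this assay, at which 1 of the 2 values shown sits, shows. Compound 1 `O=C(CCCCCc1ccccc1)OCC1COCCOCCOCCOCCOCCO1` carries a 5-phenylpentyl chain there and gives 78000 nM. Within the data shown here, the one measured comparison is an at least 1.2-fold higher number from compound 1 to compound 2 (0.10 log units; that floor lies within the scatter). Compound 3 `O=C(CCCCc1ccccc1)OCC1COCCOCCOCCOCCOCCO1` differs from compound 2 by 4-phenylbutyl in place of pyridin-3-yl on a carbonyl carbon. Because compound 1 gives 78000 nM with a closely related chain, compound 3 is expected to give 85000 nM, with a range of 40000 nM to 180000 nM, an estimated step of an at least 1.1-fold lower number from compound 2 to compound 3 (0.07 log units; that floor lies within the scatter).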

Compound 3, concentration for 50% growth inhibition: > 100000 nM
Compound 3: a limit, no number; the forecaster's own chance of this, stated with the estimate: 35%; middle value at least 1.1-fold (0.07 log units) from the limit.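

In this assay, 4-phenylbutyl on the carbonyl carbon leaves the series at a limit of the assay, not at a number, so the step between compound 2 and compound 3 cannot be read: the limit of > 100000 nM in this assay, at which 2 of the 3 values shown sit. Among these compounds, the only readable step is an at least 1.2-fold higher number from compound 1 to compound 3 (0.10 log units; that floor lies within the scatter). It therefore gives no sign that 5-phenylpentyl and 4-phenylbutyl differ in this position, and it shows that a phenylalkyl chain here does not always give a measurable value.

As far as these compounds go, whether a 6-phenylhexyl chain or a chain ending in an amine would give a clearly lower number than compound 1 stays open.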